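Halogen swap on the indole ring of a diterpenoid series

The source may report more compounds than this note shows. Statements on the series, on what has been measured and on what is new or still open speak of the compounds shown alone.

Compound 1 `COC(=O)[C@@]1(C)CCC=C2[C@@H]1CC[C@@H](C)[C@]2(C)Cc1c[nH]c2ccc(Cl)cc12` is the reference point. In a functional assay on A549 cells (Homo sapiens) for inhibition, read by sulforhodamine B assay, with a stated time of 48 h (on this read-out higher numbers stand for weaker inhibition of growth and lower numbers for stronger inhibition of growth), compound 1 gives 16000 nM. Going by the values given here, compound 2 `COC(=O)[C@@]1(C)CCC=C2[C@@H]1CC[C@@H](C)[C@]2(C)Cc1c[nH]c2ccc(F)cc12` differs from compound 1 by fluoro in place of chloro on an aromatic carbon; in this assay compound 2 gives 6200 nM, and the step of a 2.6-fold lower number from compound 1 to compound 2 (0.41 log units; beyond the scatter) is the only measured instance of this change so far. Compound 3 `COC(=O)[C@@]1(C)CCC=C2[C@@H]1CC[C@@H](C)[C@]2(C)Cc1c(C)[nH]c2ccc(Cl)cc12` differs from compound 1 by methyl in place of hydrogen on an aromatic carbon; in this assay compound 3 gives 17000 nM, and the step of a 1.1-fold higher number from compound 1 to compound 3 (0.03 log units; within the scatter) leaves compound 3 and compound 1 indistinguishable on this read-out.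

Compound 4 `COC(=O)[C@@]1(C)CCC=C2[C@@H]1CC[C@@H](C)[C@]2(C)Cc1c(C)[nH]c2ccc(F)cc12` has not been measured. It differs from compound 3 by fluoro in place of chloro on an aromatic carbon, which is the same change that carries compound 1 to compound 2; among the four compounds this change occurs two times in all, once measured and once not. The two cores differ as described by methyl in place of hydrogen on an aromatic carbon, and that difference has been seen to have no effect beyond the scatter in this assay. The expectation for compound 4 is therefore that the halogen swap will act as it did before, giving an estimated step of a 2.6-fold lower number from compound 3 to compound 4 (0.42 log units; beyond the scatter), to be set beside the measured step from compound 1 to compound 2. This rests on compound 1 being matched by compound 3 with 17000 nM. On that basis compound 4 is estimated at 6500 nM in this assay, with a plausible range from 3000 nM to 14000 nM.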

Compound 4, concentration for 50% growth inhibition: 15000 nM
Compound 4: the middle estimate sits 2.3-fold (0.36 log units) below what was measured; the measured number lies above the stated range.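

In this assay, fluoro in place of chloro on the core that carries the added methyl gives a 1.1-fold lower number from compound 3 to compound 4 (0.05 log units; within the scatter), and methyl in place of hydrogen on the fluoro compound gives a 2.4-fold higher number from compound 2 to compound 4 (0.38 log units; beyond the scatter). Set beside the earlier step, the halogen swap cannot be told apart between the two cores, even though one step lies beyond the scatter and the other within it: the same change on two cores in this assay, a 2.6-fold lower number (0.41 log units; beyond the scatter) from compound 1 to compound 2 and a 1.1-fold lower number (0.05 log units; within the scatter) from compound 3 to compound 4, 2.3-fold (0.36 log units) apart, within the scatter of two such steps. The methyl change reads the same way, so these four compounds show neither that either change carries over with a fixed size nor that its size depends on the core, and a single pair for each change cannot settle the matter: the same change on two cores in this assay, a 1.1-fold higher number (0.03 log units; within the scatter) from compound 1 to compound 3 and a 2.4-fold higher number (0.38 log units; beyond the scatter) from compound 2 to compound 4, 2.3-fold (0.36 log units) apart, within the scatter of two such steps.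

The compounds shown leave open how the series would read with a bromo, methoxy or nitrile group on the aromatic carbon that holds the halogen, and whether an ethyl group in place of the added methyl would behave as the methyl does. They also leave open whether a carboxylic acid or an amide in place of the methyl ester would shift the numbers in this assay on either core.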